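The source may report more compounds than this note shows. Statements on the series, on what has been measured and on what is new or still open speak of the compounds shown alone.

Compound 1 `CN(C)c1ccc2cc(NC(=O)CCc3ccc(C(F)(F)F)cc3)ccc2n1` gives 110 nM in a functional assay on HEK293 cells for activation of melanin-concentrating hormone receptor 1 (Rattus norvegicus), read by inositol phosphate accumulation; a lower number here means that less compound is needed, a higher number that more compound is needed for the effect.
Compound 2 `O=C(CCc1ccc(C(F)(F)F)cc1)Nc1ccc2nc(N3CCCCCC3)ccc2c1` gives 1800 nM.
Compound 3 `O=C(CCc1ccc(C(F)(F)F)cc1)Nc1ccc2nc(N3CCC3)ccc2c1` gives 56 nM.

Compound 3 has the lowest number of the three, though the step of a 2.0-fold lower number from compound 1 to compound 3 (0.29 log units; within the scatter) stays within the scatter, while the step of a 32-fold lower number from compound 2 to compound 3 (1.51 log units; beyond the scatter) lies well beyond it. Compound 4 `O=C(CCc1ccc(C(F)(F)F)cc1)Nc1ccc2nc(N3CC4CCC3CC4)ccc2c1` differs from compound 3 in one place: a group of 8 heavy atoms (7 carbon, 1 nitrogen; 2 six-membered non-aromatic rings with 1 hetero atom each) in place of a group of 4 heavy atoms (3 carbon, 1 nitrogen; one four-membered non-aromatic ring with 1 hetero atom), on an aromatic carbon. Among the compounds with values here, the steps that bear on this are a 16-fold higher number from compound 1 to compound 2 (1.21 log units; beyond the scatter) and a 32-fold lower number from compound 2 to compound 3 (1.51 log units; beyond the scatter), both large, and both in the direction that the bigger amine on that carbon gives the higher number. The entering group of compound 4 is bigger still than azepan-1-yl, so a large rise is expected, a 45-fold higher number from compound 3 to compound 4 (1.65 log units; beyond the scatter). Compound 4 is therefore estimated at 2500 nM, with a range from 600 nM to 10000 nM.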

Compound 4, half-maximal effective concentration: 190 nM
Compound 4: the middle estimate sits 13-fold (1.12 log units) above what was measured, outside the stated range (below it).
By their numbers in this assay, from the lowest: compounds 3, 1 and 4 (each within the scatter of the next, the first and the last beyond it); then compound 2.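

At this position on an aromatic carbon, heavy-atom count alone does not set the number in this assay: the group of 8 heavy atoms, with its 2 six-membered non-aromatic rings, goes against the rise seen with azepan-1-yl, giving a 9.5-fold lower number from compound 2 to compound 4 (0.98 log units; beyond the scatter). The same group still stands apart from azetidin-1-yl, with a 3.4-fold higher number from compound 3 to compound 4 (0.53 log units; beyond the scatter), whereas a 1.7-fold higher number from compound 1 to compound 4 (0.24 log units; within the scatter) leaves it within the scatter of dimethylamino. Nothing available accounts for this difference between the ring groups.

Going by these compounds, whether pyrrolidin-1-yl, piperidin-1-yl or morpholin-4-yl on this carbon would fall nearer azetidin-1-yl or azepan-1-yl remains open.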